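Oxanylmethyl for Hydroxymethylpropyl on Two Amine Cores

The source may hold more compounds than are shown below. What is called first, only, known or untested is meant among the compounds shown, and "the series" means these compounds.

Compound 1 `CC(C)c1nc(C(=O)NCC2(O)CCN(CC3CCOCC3)CC2)c2ccccn12`: 56.7 nM
Compound 2 `CC(C)c1nc(C(=O)NCC2(O)CCN(CC(C)(C)O)CC2)c2ccccn12`: 72.3 nM
Compound 3 `CC(C)c1nc(C(=O)NC2C3CN(CC(C)(C)O)CC32)c2ccccn12`: > 10000 nM

In a functional assay on CHO cells for agonist activity at 5-hydroxytryptamine receptor 4 (Homo sapiens), read by a luciferase reporter and cAMP accumulation, with a stated time of 4 h (on this read-out higher numbers stand for an effect only at larger amounts of compound and lower numbers for an effect already at smaller amounts), compound 1 gives 56.7 nM and compound 2 gives 72.3 nM. Compound 3 gives only a limit, > 10000 nM. That limit is the limit of > 10000 nM in this assay, at which 1 of the 3 values shown sits. The change from compound 2 to compound 1 is oxan-4-yl in place of 1-hydroxy-1-methylethyl on a saturated chain carbon bound to an amine nitrogen in a ring and it made a 1.3-fold lower number from compound 2 to compound 1 (0.11 log units; within the scatter). The difference between the cores of compound 2 and compound 3 is not broken down here. Compound 4 `CC(C)c1nc(C(=O)NC2C3CN(CC4CCOCC4)CC32)c2ccccn12` carries the same change on the core of compound 3: oxan-4-yl in place of 1-hydroxy-1-methylethyl on a saturated chain carbon bound to an amine nitrogen in a ring. Because compound 3 sits at the limit of > 10000 nM in this assay, at which 1 of the 3 values shown sits, and the earlier step was a 1.3-fold lower number from compound 2 to compound 1 (0.11 log units; within the scatter), compound 4 is expected to stay at or near that limit. The estimate corresponds to a step that the limit leaves unreadable from compound 3 to compound 4, expected to lie within the scatter. Compound 4 is estimated at 12000 nM, between 4000 nM and 40000 nM.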

Compound 4, half-maximal effective concentration: 1060 nM
Beside the measured number, compound 4's estimate is 11-fold (1.05 log units) above it; measured number outside the range, below it.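

On the core of compound 3, oxan-4-yl in place of 1-hydroxy-1-methylethyl gave an at least 9.4-fold lower number from compound 3 to compound 4 (0.97 log units; beyond the scatter). Compound 3 gives > 10000 nM, which is a limit and not a number. The change therefore did not carry over with the same size from one core to the other, although two cores show only that its size differed here, not how it would run on any further core: the same change on two cores in this assay, a 1.3-fold lower number (0.11 log units; within the scatter) from compound 2 to compound 1 and an at least 9.4-fold lower number (0.97 log units; beyond the scatter) from compound 3 to compound 4, at least 7.3-fold (0.86 log units) apart, beyond the scatter of two such steps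

The compounds shown leave open how a 2-methoxyethyl or a cyclohexylmethyl group would read in place of (oxan-4-yl)methyl on either core. They also leave open whether the larger step would recur on a third core.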